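The source may hold more compounds than are shown below. What is called first, only, known or untested is meant among the compounds shown, and "the series" means these compounds.

Measured so far in an assay for inhibition of Amine oxidase [flavin-containing] B (Rattus norvegicus); on this read-out higher numbers stand for weaker inhibition and lower numbers for stronger inhibition:
compound 1 `Cc1cccc(COc2ccc(-c3nn(CCC#N)c(=S)o3)cc2)c1` gives 66 nM
compound 2 `N#CCn1nc(-c2ccc(OCc3ccccc3)cc2)oc1=O` gives 60 nM

Compound 2 holds the lower of the two numbers, but compound 1 sits within the scatter of it, so no order between the two can be read. The pair also differs in more than one place, so it isolates no single change on the shared core.

Compound 3 `N#CCCCCn1nc(-c2ccc(OCc3ccccc3)cc2)oc1=O` follows from compound 2 by 3-cyanopropyl in place of cyano on a saturated chain carbon bound to an aromatic nitrogen. Going by the values given here, no measured pair isolates a change of this kind. Compounds 1 and 2 both carry a nitrile-terminated chain on the core and give closely similar numbers, which offers weak support for tolerance of such chains, though that pair is not a clean comparison. The step from compound 2 to compound 3 in this assay is therefore expected to stay near the scatter or to move slightly toward weaker inhibition, as a 1.4-fold higher number from compound 2 to compound 3 (0.15 log units; within the scatter). Compound 3 is expected at 85 nM, with a range from 25 nM to 300 nM.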

Compound 3, half-maximal inhibitory concentration: 490 nM
Compound 3: middle estimate off by 5.8-fold (0.76 log units), on the low side; measured number above the stated range.
By their numbers in this assay, from the lowest: compounds 2 and 1 (each within the scatter of the next); then compound 3.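

In this assay, going by these compounds alone, the change to 3-cyanopropyl in place of cyano gives an 8.2-fold higher number from compound 2 to compound 3 (0.91 log units; beyond the scatter) and is the first single-place step, on a saturated chain carbon bound to an aromatic nitrogen. Read one bond further out, as cyanomethyl to 4-cyanobutyl, the step shows that keeping a nitrile at the end of the chain does not by itself preserve the number at this position, so the similar values of compound 1 and compound 2 cannot be taken as general tolerance of such chains. The nitrile and the hydrogen-bond donor and acceptor counts stay the same across the step while the group grows from 2 heavy atoms to 5, but nothing available bears on the reason for the higher number.

On these data alone, with only these two chains compared on one core, it remains open whether the number rises gradually or abruptly with chain length, and whether a longer chain would continue the trend. A chain of the same length ending in an amine or a carboxylic acid would be needed to separate the role of chain length from that of the nitrile, and the size of the step on the core of compound 1 is also unknown.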